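The source may hold more compounds than are shown below. What is called first, only, known or untested is meant among the compounds shown, and "the series" means these compounds.

Measured compounds:
compound 1, `CCO/C(O)=C1\C(C)=NC(COCCNc2n[nH]c(N)n2)=C(C(=O)OC)C1c1cccc(Cl)c1Cl`, 100 nM
compound 2, `CCOC(=O)NC(=S)NCCOCC1=C(C(=O)OCC)C(c2cccc(Cl)c2Cl)/C(=C(\O)OC)C(C)=N1`, 31.6 nM
compound 3, `CCO/C(O)=C1\C(COCCNc2nc(O)cs2)=NC(C)=C(C(=O)OC)C1c1cccc(Cl)c1Cl`, 20 nM

All three were tested in a functional assay (aorta) with Rattus norvegicus as the target; a higher number here means a weaker inhibitor, a lower number a stronger inhibitor. Compound 3 has the lowest number of the three. Its nearest neighbour is compound 2, whose value sits within the usual scatter of compound 3, so no order between these two can be claimed. Going by the values given here, compound 1 stands furthest away, with a number beyond the scatter from compound 3; only for this pair does the data show a real gap, and no single-point step connects compound 1 to compound 3.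

Compound 4, `CCO/C(O)=C1\C(COCCNc2n[s+]([O-])nc2N)=NC(C)=C(C(=O)OC)C1c1cccc(Cl)c1Cl`, has not yet been measured. It differs from compound 3 in one place: a group of 7 heavy atoms (2 carbon, 3 nitrogen, 1 oxygen, 1 sulfur; one five-membered aromatic ring with 3 hetero atoms) in place of a group of 6 heavy atoms (3 carbon, 1 nitrogen, 1 oxygen, 1 sulfur; one five-membered aromatic ring with 2 hetero atoms), on an amine nitrogen. The rest of the molecule, including the shared core and the chain carrying the amine nitrogen, is unchanged.

Among the compounds with values here, no measured pair isolates this particular exchange, so the size of the step is uncertain. The expectation is a small move toward a higher number, near the edge of the scatter, a 2.0-fold higher number from compound 3 to compound 4 (0.30 log units; within the scatter). Compound 4 is therefore estimated at 40 nM, with a range from 12 nM to 130 nM.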

Compound 4, half-maximal inhibitory concentration: 15.9 nM
Compound 4: middle estimate off by 2.5-fold (0.40 log units), on the high side; measured number inside the range.
By their numbers in this assay, from the lowest: compounds 4, 3 and 2 (each within the scatter of the next); then compound 1.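

In this assay, putting the new five-membered aromatic ring with 3 hetero atoms on the amine nitrogen, in place of 4-hydroxy-1,3-thiazol-2-yl, gives a step of a 1.3-fold lower number from compound 3 to compound 4 (0.10 log units; within the scatter), so the two compounds cannot be placed in any order. Going by these compounds alone, this is the first comparison that isolates a single place, and it shows that this position accepts two different five-membered aromatic rings with values that cannot be told apart, although the rings differ in their atoms and in their count of hydrogen-bond acceptors. Nothing measured here offers an explanation for this result.

The comparison covers only these two rings, both five-membered and aromatic, so it cannot show how much freedom this position really has. An unsubstituted phenyl ring, a six-membered pyridine ring or a simple acetyl group on the amine nitrogen, or a longer chain carrying that nitrogen, would test whether the value in this assay depends on having such a ring there at all.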